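Fluoropiperidine to Dimethylmorpholine on the Amide Carbonyl

A few compounds are considered here, and "the series" means these few. Any claim that something is new, unique, unknown or untested is made for them only; others in the source may bear on it.

Measured so far:
- compound 1, `O=S(=O)(c1ccc(Cl)cc1)N1CC(c2nc(-c3cccc(Cl)c3)no2)C1`: > 10000 nM
- compound 2, `O=C(N1CCC(F)CC1)N1CC(c2nc(-c3cccc(Cl)c3)no2)C1`: 990 nM
- compound 3, `O=C([C@H]1CC2CCC1C2)N1CC(c2nc(-c3cccc(F)c3)no2)C1`: 72 nM

All three share a core and were tested in an assay on HEK293 cells for positive allosteric modulation of metabotropic glutamate receptor 5 (Homo sapiens), read by FLIPR; on this read-out higher numbers stand for an effect only at larger amounts of compound and lower numbers for an effect already at smaller amounts. For compound 1 the result is only a limit of the assay, (the limit of > 10000 nM in this assay, at which 1 of the 3 values shown sits), and not a number. Of the two numbers, compound 2 has the higher one, and compound 3 sits far lower, beyond the usual scatter.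

Compound 4, `CC1CN(C(=O)N2CC(c3nc(-c4cccc(Cl)c4)no3)C2)CC(C)O1`, has not been measured. It differs from compound 2 in one place: 2,6-dimethylmorpholin-4-yl in place of 4-fluoropiperidin-1-yl on a carbonyl carbon. Both rings are six-membered and attach through the ring nitrogen to the same carbonyl carbon, so the shape of the compound changes little. For the measured compounds named here, no measured pair shows what such a swap does here, so the expectation rests on the similarity of the two groups. The step from compound 2 to compound 4 is expected to be small, a 1.0-fold higher number from compound 2 to compound 4 (0.00 log units; within the scatter), in no firm direction beyond the scatter. Compound 4 is therefore estimated at 1000 nM, within a range from 300 nM to 3500 nM.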

Compound 4, half-maximal effective concentration: > 10000 nM
Compound 4: no number, only a limit; the forecaster's own chance of this, stated with the estimate: 10%; middle value at least 10-fold (1.00 log units) away from the limit.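

In this assay, this position on the carbonyl carbon does not accept every six-membered ring joined through its nitrogen: 2,6-dimethylmorpholin-4-yl in place of 4-fluoropiperidin-1-yl gives an at least 10-fold higher number from compound 2 to compound 4 (1.00 log units; beyond the scatter). Two rings of the same size with the same point of attachment can therefore differ widely here, so ring size and attachment alone do not settle the result. The result for compound 4 is a limit and not a number, so the step has only a lower bound: the limit of > 10000 nM in this assay, at which 2 of the 4 values shown sit.

The swap removes the fluorine and adds both the ring oxygen and the methyl groups, and the compounds shown cannot tell which of these changes matters. Plain morpholin-4-yl, without the methyl groups, on the same carbonyl carbon would help to separate the effect of the ring oxygen from that of the methyl groups.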